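Hydroxamate series: chloro added to the terminal phenyl

The source may hold more compounds than are shown below. What is called first, only, known or untested is meant among the compounds shown, and "the series" means these compounds.

Measured so far in an assay on isolated protein for inhibition of sphingomyelin phosphodiesterase (Homo sapiens), read by fluorescence, with a stated time of 30 min; on this read-out lower numbers stand for stronger inhibition and higher numbers for weaker inhibition:

compound 1, `O=C(NO)c1cccc(OCc2ccc(-c3cccnc3)cc2)c1`, gives 52300 nM
compound 2, `CCc1nc(-c2ccc(COc3cccc(C(=O)NO)c3)cc2)no1`, gives 34700 nM
compound 3, `COc1ccc(C(=O)NO)cc1OCc1noc(-c2ccccc2)n1`, gives 36500 nM

Compound 3 holds the second highest of the three numbers. Its value and that of compound 2 lie within the scatter of each other, as do its value and that of compound 1; the three compounds cannot be ordered on these data.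

Among the compounds with values here, the one step between measured compounds that differ in a single place is a 1.5-fold lower number from compound 1 to compound 2 (0.18 log units; within the scatter), a swap of one aryl group for another on the same aromatic carbon, and it stays within the scatter.

Compound 4, `COc1ccc(C(=O)NO)cc1OCc1noc(-c2cccc(Cl)c2)n1`, differs from compound 3 by chloro in place of hydrogen on an aromatic carbon. Within the data shown here, no measured step bears directly on a halogen added to this ring; the only measured step, from compound 1 to compound 2, changed a different part of the molecule and produced no movement beyond the scatter. Among the measured compounds shown here, with no precedent pointing either way, the expectation is a step of about a 1.2-fold lower number from compound 3 to compound 4 (0.09 log units; within the scatter), that is, none beyond the scatter.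

Compound 4 is therefore expected to give roughly 30000 nM in this assay, with a range from 12000 nM to 75000 nM.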

Compound 4, half-maximal inhibitory concentration: 9220 nM
Estimate against measurement, compound 4: 3.3-fold (0.51 log units) above; the whole stated range lies above it.
By their numbers in this assay, from the lowest: compound 4; then compounds 2, 3 and 1 (each within the scatter of the next).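

In this assay, within the data shown here, the change from phenyl to 3-chlorophenyl gives a 4.0-fold lower number from compound 3 to compound 4 (0.60 log units; beyond the scatter), which goes beyond the scatter, whereas the only earlier step, a 1.5-fold lower number from compound 1 to compound 2 (0.18 log units; within the scatter), stays within it. Among these compounds, the phenyl of compound 3 is therefore a place where one added heavy atom moves the number, something the aryl swap between the two earlier compounds could not show, and compound 4 at 9220 nM is the only example of that movement so far. No measured information bears on why chloro at this place lowers the number.

Going by these compounds, whether the step belongs to chloro itself or would also appear with fluoro, methyl, methoxy or trifluoromethyl on the same carbon remains open, as does the effect of chloro elsewhere on the phenyl. Also open, on these data alone, is whether the step carries over to a core with a different substituent in place of the methoxy group, or to a compound with a carboxylic acid in place of the hydroxamic acid.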